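Swapping an Aryl Group for a Styryl Chain

The source may hold more compounds than are shown below. What is called first, only, known or untested is meant among the compounds shown, and "the series" means these compounds.

Measured compounds:
- Compound 1, `Cc1c(Br)sc(N)c1C(=O)c1ccc(Cl)cc1`: 1%
- Compound 2, `Cc1sc(N)c(C(=O)c2ccc(Cl)cc2)c1-c1ccccc1`: 1%
- Compound 3, `CC(C)(C)Cc1c(-c2ccc(F)cc2)sc(N)c1C(=O)c1ccc(Cl)cc1`: 9%

All three compounds share a five-membered aromatic core carrying an amino group and a (4-chlorophenyl)carbonyl group, and all were tested in an assay on CHO cells for displacement of a labelled ligand from adenosine receptor A3 (Homo sapiens), read by scintillation counting, tested at 10 uM; a lower number here means less inhibition, a higher number more inhibition at the concentration tested (going by the name of the read-out). In this assay compound 1 gives 1%, compound 2 gives 1% and compound 3 gives 9%. The three numbers sit close together: the gaps between compound 3 and compound 1, and between compound 3 and compound 2, both fall within the usual scatter of repeated measurements, so none of the three can be set apart from the others.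

Compound 4, `CC(C)(C)Cc1c(/C=C/c2ccc(Cl)cc2)sc(N)c1C(=O)c1ccc(Cl)cc1`, has not yet been measured. It differs from compound 3 in a single place: 2-(4-chlorophenyl)ethenyl in place of 4-fluorophenyl on an aromatic carbon. Going by the values given here, no earlier pair of measured compounds shows what such a change does in this assay, so there is no measured step to lean on. With all three measured numbers so low and so alike, the expectation is that the step of a number 1 percentage points higher from compound 3 to compound 4 (within the scatter) stays small, with no change beyond the scatter in either direction. Compound 4 is therefore estimated to give 10%, within a range from -5% to 30%.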

Compound 4, a percentage reported as inhibition, at one concentration (the size of the read-out at that concentration, not a potency): 11%
Compound 4: middle estimate off by 1 percentage points, on the low side; the range from low to high includes it.
By their numbers in this assay, from the lowest: compounds 1, 2, 3 and 4 (each within the scatter of the next).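

Going by these compounds alone, putting 2-(4-chlorophenyl)ethenyl in place of 4-fluorophenyl, on the aromatic carbon next to the ring sulfur, gives a number 2 percentage points higher from compound 3 to compound 4 (within the scatter) in this assay and is the first single-place change that can be read. At this position, then, the longer group with its double bond outside the ring leaves the number within the scatter of the one given by the directly attached aryl group. No measurement is available that would explain this result.

The step swaps the halogen and adds the double bond together, so the compounds shown leave open what each change does alone. Also open, as far as these compounds go, is whether an amine or a carboxylic acid on this carbon would move the number beyond the scatter.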